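A few compounds are considered here, and "the series" means these few. Any claim that something is new, unique, unknown or untested is made for them only; others in the source may bear on it.

Of the compounds shown here, two built on one shared core have been measured in an ADME assay on microsomes from liver (Rattus norvegicus) for metabolic stability, read by LC-MS, with a stated time of 30 min, tested at 0.1 uM; on this read-out lower numbers stand for a less stable compound and higher numbers for a more stable compound. Compound 1 `COc1cccnc1Nc1cc2[nH]c(-c3cccc(C(F)(F)F)c3)nc2cn1` gives 83% in this assay. Compound 2 `FC(F)(F)c1cccc(-c2nc3cnc(Nc4cnccn4)cc3[nH]2)c1` differs from compound 1 only in the group carried on a nitrogen attached to an aromatic ring; in this assay compound 2 gives 20%. That single exchange produced a number 63 percentage points lower from compound 1 to compound 2 (beyond the scatter), so compound 2 stands as the lower of the two numbers, with compound 1 sitting well beyond the usual scatter above it.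

Compound 3 `N#Cc1ccc(Nc2cc3[nH]c(-c4cccc(C(F)(F)F)c4)nc3cn2)nc1` has not yet been measured. It differs from compound 2 by 5-cyanopyridin-2-yl in place of pyrazin-2-yl on a nitrogen on an aromatic ring. Within the data shown here, only one measured step touches this position, the exchange from compound 1 to compound 2, and it was large, showing that the group on that nitrogen can move the read-out strongly. Among the measured compounds shown here, no measured step shows what a 5-cyanopyridin-2-yl group does on its own, so the direction remains uncertain. Taking the large swing seen between compound 1 and compound 2 as the only guide, a rise of moderate size is expected for compound 3, on the order of a number 25 percentage points higher from compound 2 to compound 3 (beyond the scatter), giving an estimated 45% in this assay with a range from 15% to 80%.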

Compound 3, percent of the compound remaining: 49%
The estimate for compound 3 lay 4 percentage points below the measured number; low and high end bracket the measured number.
By their numbers in this assay, from the lowest: compound 2; then compound 3; then compound 1.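

In this assay, 5-cyanopyridin-2-yl in place of pyrazin-2-yl on the nitrogen gives a number 29 percentage points higher from compound 2 to compound 3 (beyond the scatter), while 5-cyanopyridin-2-yl in place of 3-methoxypyridin-2-yl gives a number 34 percentage points lower from compound 1 to compound 3 (beyond the scatter), which places compound 3 in the middle of the series. The group on this nitrogen therefore does more than separate one high level from one low level: three different groups now give three levels, and each gap lies beyond the scatter. Nothing measured here explains this order.

All three groups on this nitrogen are six-membered aromatic rings containing ring nitrogen, so the compounds leave open what a plain phenyl ring, a saturated piperidine ring or a short chain such as ethyl would do at this position. They also leave open how much the methoxy group and the nitrile contribute on their own, as each arrives on a different ring and an unsubstituted pyridin-2-yl group would be needed to compare them with a common parent.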